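The compounds below may be only part of what the source reports. "The series", "measured", "known", "first", "only" and "open" are said of these compounds alone.

Measured so far:
Compound 1, `O=C(Nc1cccc(-n2cc(-c3ccncc3)c(-c3cc(O)cc(Cl)c3)n2)c1)Nc1ccc(Cl)c(C(F)(F)F)c1`, gives 97%.
Compound 2, `O=C(Nc1cccc(-n2cc(-c3ccncc3)c(-c3cc(O)cc(Cl)c3)n2)c1)Nc1ccc(Cl)c(Cl)c1`, gives 96%.
Compound 3, `COc1cc(Cl)cc(-c2nn(-c3cccc(NC(=O)Nc4ccc(Cl)c(C(F)(F)F)c4)c3)cc2-c2ccncc2)c1`, gives 95%.

These numbers come from a functional assay on MDA-MB-435 cells (Homo sapiens) for inhibition, read by sulforhodamine B assay, with a stated time of 48 h, tested at 0.01 uM (a lower number here means a stronger effect, a higher number a weaker effect of the compound at the concentration tested), and compound 3 holds the smallest of the three, but its gaps to compound 2 and to compound 1 both lie within the usual scatter, so the three compounds cannot be told apart on these numbers.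

Compound 4, `COc1cc(Cl)cc(-c2nn(-c3cccc(NC(=O)Nc4ccc(Cl)c(Cl)c4)c3)cc2-c2ccncc2)c1`, differs from compound 3 in one place: chloro in place of trifluoromethyl on an aromatic carbon. The same exchange has already been seen once, between compound 1 and compound 2, where it gave a number 1 percentage points lower from compound 1 to compound 2 (within the scatter). The other measured step, a number 2 percentage points lower from compound 1 to compound 3 (within the scatter), concerns the group on the oxygen and does not bear on this change.

With one directly comparable step that stayed within the scatter, no shift beyond the scatter is expected from compound 3 to compound 4, that is no change at the digits printed from compound 3 to compound 4 (within the scatter). The expected value for compound 4 is therefore 95%, with a range from 86% to 100%.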

Compound 4, a percentage reported as activity, at one concentration (the size of the read-out at that concentration, not a potency): 93%
The estimate for compound 4 lay 2 percentage points above the measured number, within the range that was stated.
By their numbers in this assay, from the lowest: compounds 4, 3, 2 and 1 (each within the scatter of the next).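

In this assay, the exchange of trifluoromethyl for chloro on this aromatic carbon now gives a number 2 percentage points lower from compound 3 to compound 4 (within the scatter), this time with a methyl rather than a hydrogen on the oxygen, so the change has been read in two settings: the same change on two cores in this assay, a number 1 percentage points lower (within the scatter) from compound 1 to compound 2 and a number 2 percentage points lower (within the scatter) from compound 3 to compound 4, 1 percentage points apart, within the scatter of two such steps. Likewise, methyl in place of hydrogen on the oxygen gives a number 3 percentage points lower from compound 2 to compound 4 (within the scatter), this time with the 3,4-dichlorophenyl group rather than the 4-chloro-3-(trifluoromethyl)phenyl group: the same change on two cores in this assay, a number 2 percentage points lower (within the scatter) from compound 1 to compound 3 and a number 3 percentage points lower (within the scatter) from compound 2 to compound 4, 1 percentage points apart, within the scatter of two such steps. Across these four compounds, each change reads alike whichever group stands at the other place, and neither step leaves the scatter.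

All four compounds were read at one concentration, so these numbers cannot show whether the changes would matter at a concentration where the values spread further apart. Going by these compounds, how an amine or a nitrile on this aromatic carbon, or a longer chain on the oxygen, would behave also stays open.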